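From chloro to bromo: a small step expected

The source may hold more compounds than are shown below. What is called first, only, known or untested is meant among the compounds shown, and "the series" means these compounds.

In a physicochemical assay for lipophilicity (on this read-out lower numbers stand for lower lipophilicity and higher numbers for higher lipophilicity), compound 3 `Clc1ccccc1C1=NC(c2ccccc2)CO1` gives 3.56 and stands close to compound 1 `Fc1cccc(Cl)c1C1=NC(c2ccccc2)CO1` at 3.45 while compound 2 `Clc1cccc(C2=NC(c3ccccc3)CO2)c1Cl` reaches 4.28 on the same scale. Going from compound 3 to compound 4 `Brc1ccccc1C1=NC(c2ccccc2)CO1` puts bromo in place of chloro on an aromatic carbon, ortho to a large group, as counted in bromo in place of chloro on an aromatic carbon and no measured step shows this exact exchange. Two steps that each remove a halogen offer a loose guide: hydrogen in place of fluoro gave a number 0.11 log units higher from compound 1 to compound 3 (within the scatter) and hydrogen in place of chloro gave a number 0.72 log units lower from compound 2 to compound 3 (beyond the scatter) and an exchange that keeps a halogen in place should be smaller than that second step. In this assay the expected change is a number 0.14 log units higher from compound 3 to compound 4 (within the scatter) and this small rise may not clear the scatter. Compound 4 is estimated at 3.7 with an expected range from 3.4 to 4 in this measurement.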

Compound 4, partition coefficient: 3.69
For compound 4 the middle estimate is 0.01 log units above the measured one; measured number inside the range.
By their numbers in this assay, from the lowest: compounds 1, 3 and 4 (each within the scatter of the next); then compound 2.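

At this position, on an aromatic carbon ortho to a large group, this assay now shows a direct exchange of one halogen for another: bromo in place of chloro gives a number 0.13 log units higher from compound 3 to compound 4 (within the scatter). On this read-out, compound 4 cannot be told apart from compound 3. Nothing measured here explains this result. From the compounds shown here alone, whether an amine or a carboxylic acid at this position would stay as close to compound 3 remains open, as does whether the same exchange would give a similar step elsewhere on the shared core.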